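The source may hold more compounds than are shown below. What is called first, only, known or untested is meant among the compounds shown, and "the series" means these compounds.

In a functional assay on MCF7 cells (Homo sapiens) for antiproliferative activity (a higher number here means a weaker inhibitor, a lower number a stronger inhibitor), compound 1 `Cc1ccc(C(=O)Nc2ccc(O)c3c(=O)cc(-c4ccccc4Cl)oc23)cc1` gives 10000 nM and compound 2 `CS(=O)(=O)Nc1ccc(O)c2c(=O)cc(-c3ccccc3Cl)oc12` gives 25000 nM, the higher of the two numbers. Compound 3 `O=c1cc(-c2ccccc2Cl)oc2c(NS(=O)(=O)c3ccccc3)ccc(O)c12` differs from compound 2 by phenyl in place of methyl on a sulfonyl sulfur, with phenyl in place of methyl on a sulfonyl sulfur. For the measured compounds named here, only one measured step bears on this, and only indirectly: a 2.5-fold higher number from compound 1 to compound 2 (0.40 log units; beyond the scatter), a modest step that also removes a ring. Restoring a ring may therefore lean back towards compound 1 at 10000 nM, though a single pair is thin evidence. The estimated change is small, a 1.8-fold lower number from compound 2 to compound 3 (0.25 log units; within the scatter). Compound 3 is expected near 14000 nM, within an estimated range of 5000 nM to 35000 nM.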

Compound 3, half-maximal inhibitory concentration: 16000 nM
Compound 3: middle estimate off by 1.1-fold (0.06 log units), on the low side; the measured number falls inside the stated range.
By their numbers in this assay, from the lowest: compounds 1, 3 and 2 (each within the scatter of the next, the first and the last beyond it).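

In this assay phenyl in place of methyl on the sulfonyl sulfur gives a 1.6-fold lower number from compound 2 to compound 3 (0.19 log units; within the scatter) and so does not separate these two sulfonamides. Phenylsulfonyl in place of (4-methylphenyl)carbonyl on the nitrogen gives a 1.6-fold higher number from compound 1 to compound 3 (0.20 log units; within the scatter) and so leaves compound 3 indistinguishable from compound 1 as well. No supporting measurement is available to explain either result.

The compounds shown leave open whether a longer chain or an amine on the sulfonyl sulfur would give a step beyond the scatter from compound 2.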